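This account rests on a few compounds, and the source may have more. Where it says the series, first, only, none or still open, it means among the compounds named here.

Measured compounds and their values:

compound 1 `CCOC(=O)[C@](C)(Cc1ccccc1)c1c(C)cnc2c(-c3ccc(C(F)(F)F)cc3)cnn12` — 80%
compound 2 `CCOC(=O)[C@](C)(Cc1ccccc1)c1cc(C)nc2c(-c3ccc(Cl)cc3)cnn12` — 15%

In a functional assay on CHO cells for agonist activity at Glucose-dependent insulinotropic receptor (Homo sapiens), read by HTRF and cAMP accumulation (on this read-out higher numbers stand for larger maximal responses and lower numbers for smaller maximal responses), compound 1 gives 80%, the higher of the two numbers recorded in this assay. Compound 2 gives 15%, a number that lies well beyond the usual scatter below compound 1. The two differ in more than one place, so nothing is drawn from that gap on any single change.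

Compound 3 `CCOC(=O)[C@](C)(Cc1ccccc1)c1c(Cl)cnc2c(-c3ccc(C(F)(F)F)cc3)cnn12` has not yet been measured in this assay. It is obtained from compound 1 by a single change: chloro in place of methyl on an aromatic carbon

Among the compounds with values here, no measured pair isolates this change, so the size of the step is open. The chloro group is the same size as the methyl it replaces, and a large step in either direction is not expected; a modest loss is considered more likely than a gain. The step from compound 1 to compound 3 in this assay is expected to be a number 20 percentage points lower from compound 1 to compound 3 (beyond the scatter). Compound 3 is estimated at 60%, within a range of 20% to 95%.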

Compound 3, largest response reached (reported as efficacy), in percent of the reference or control that the assay uses: 75%
The estimate for compound 3 lay 15 percentage points below the measured number, and the stated range covers the measured number.
By their numbers in this assay, from the lowest: compound 2; then compounds 3 and 1 (each within the scatter of the next).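

In this assay, within the data shown here, the change to chloro gives a number 5 percentage points lower from compound 1 to compound 3 (within the scatter) and is the first step that can be read at a single place. On the core of compound 1, the aromatic carbon ortho to a large group therefore carries either methyl or chloro with no difference in maximal response beyond the scatter, which the earlier pair, differing in more than one place, could not show. Nothing available bears on why the two groups read alike.

From the compounds shown here alone, whether this holds for other groups at the same carbon, such as an amine, a methoxy group or a nitrile, stays open. The gap between compound 1 and compound 2 still cannot be read on any single change.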